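The compounds below may be only part of what the source reports. "The series", "measured", "known", "first", "only" and "open" are said of these compounds alone.

Compound 1 `CCn1nccc1-c1ccccc1NCC1=NCCN1` and compound 2 `CC(C)n1nccc1-c1ccccc1NCC1=NCCN1` share one core, while compound 3 `Cn1cc(-c2ccccc2NCC2=NCCN2)cn1` is built on a different core; the difference between the two cores is not broken down here. All three were tested in an in vitro functional assay on cells (Fibroblast) for agonist activity at Alpha-1D adrenergic receptor (Homo sapiens) (a higher number here means that more compound is needed for the effect, a lower number that less compound is needed), and in every case the result is a limit of the assay rather than a number.

In this assay compound 1 gives < 100000 nM, which is a limit. In this assay compound 2 gives < 100000 nM, again a limit. In this assay compound 3 gives < 100000 nM, also a limit. The change from compound 1 to compound 2 is methyl in place of hydrogen on a saturated chain carbon bound to an aromatic nitrogen and a saturated chain carbon, and its step is a step that the two limits leave unreadable from compound 1 to compound 2. The reason the step cannot be read is the limit of < 100000 nM in this assay, at which 3 of the 3 values shown sit, so nothing can be said about its direction or size.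

Compound 4 `CCn1cc(-c2ccccc2NCC2=NCCN2)cn1` has not yet been measured. For the measured compounds named here, it differs from compound 3 by methyl in place of hydrogen on a saturated chain carbon bound to an aromatic nitrogen, a change of the same kind as the one from compound 1 to compound 2, though the place is not identical: in compound 1 the carbon that takes the methyl is bound to an aromatic nitrogen and a saturated chain carbon, whereas in compound 3 it is bound only to an aromatic nitrogen. Because the step from compound 1 to compound 2 is a step that the two limits leave unreadable from compound 1 to compound 2, the step from compound 3 to compound 4 is expected to be a step that the limit leaves unreadable from compound 3 to compound 4. Compound 4 is therefore estimated at 10000 nM in this assay, with the real outcome most likely to be another limit.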

Compound 4, half-maximal effective concentration: < 100000 nM
Compound 4 gave a limit, no number; the forecaster's own chance of this, stated with the estimate: 80%; the middle value is on the limit's open side.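

In this assay compound 4 gives < 100000 nM, which is a limit and not a number. No step can therefore be read from compound 3 to compound 4, and the reason is the same as for the earlier pair: the limit of < 100000 nM in this assay, at which 4 of the 4 values shown sit. The compounds shown leave open how any of the four compares with another, and whether methyl in place of hydrogen changes the result in this assay at all.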